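The source may report more compounds than this note shows. Statements on the series, on what has been measured and on what is new or still open speak of the compounds shown alone.

Compounds tested in an ADME assay on MOLT-3 cells (Homo sapiens) for cytotoxicity, with a stated time of 7 days; on this read-out higher numbers stand for lower toxicity in this test and lower numbers for higher toxicity in this test:
Compound 1 `CC(C)Nc1nc(N)nc2c1ncn2/C=C1/CC1(CO)CO`: "not determined" (no result reported)
Compound 2 `CC(C)CNc1nc(N)nc2c1ncn2/C=C1/CC1(CO)CO`: "not determined" (no result reported)
Compound 3 `Nc1nc(SC2CCCC2)c2ncn(/C=C3/CC3(CO)CO)c2n1`: > 20000 nM

Of these three, only compound 3 has a result. Compound 3 stands at > 20000 nM, which is a limit of this assay and not a number.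

Compound 4 `CCCCSc1nc(N)nc2c1ncn2/C=C1/CC1(CO)CO` carries butyl in place of cyclopentyl on a sulfur. Among the compounds with values here, no measured pair shows what such a change does, so no step beyond the usual scatter is expected in this assay. The estimated change is a step that the limit leaves unreadable from compound 3 to compound 4. For compound 4 the expected value is 25000 nM, with an estimated range of 8000 nM to 60000 nM.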

Compound 4, half-maximal cytotoxic concentration: > 20000 nM
Compound 4 was reported as a limit (the forecaster's own chance of this, stated with the estimate: 65%); the middle value lies beyond the limit too.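

Within the data shown here, compound 3 and compound 4 both stand at a limit and not at a number, so no step between them can be read: the limit of > 20000 nM in this assay, at which 2 of the 4 values shown sit. The compounds shown leave open whether butyl in place of cyclopentyl on a sulfur changes this read-out at all.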